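The source may report more compounds than this note shows. Statements on the series, on what has been measured and on what is new or still open speak of the compounds shown alone.

Measured so far in a functional assay on MIA PaCa-2 cells (Homo sapiens) for inhibition, read by MTT assay, with a stated time of 3 days; a lower number here means a stronger inhibitor, a higher number a weaker inhibitor:
compound 1 `O=C([C@@H]1CCCN(S(=O)(=O)c2ccc(S(=O)(=O)C3CCC3)cc2)C1)N1CCC(F)(F)CC1` — 12.6 nM
compound 2 `O=C([C@@H]1CCCN(S(=O)(=O)c2ccc(S(=O)(=O)N3CC[C@@H](O)C3)cc2)C1)N1CCC(F)(F)CC1` — 135 nM
compound 3 `CCN(CC)S(=O)(=O)c1ccc(S(=O)(=O)N2CCC[C@@H](C(=O)N3CC[C@@H](OC)C3)C2)cc1` — 1070 nM

Compound 3 gives the highest number of the three; compound 2 lies nearest, compound 1 furthest, both gaps beyond the scatter. Compound 4 `CCN(CC)S(=O)(=O)c1ccc(S(=O)(=O)N2CCC[C@@H](C(=O)N[C@H]3CCOC3)C2)cc1` differs from compound 3 in one place: (oxolan-3-yl)amino in place of 3-methoxypyrrolidin-1-yl on a carbonyl carbon.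

Among the compounds with values here, the only measured step, an 11-fold higher number from compound 1 to compound 2 (1.03 log units; beyond the scatter), concerns a sulfonyl substituent, not the carbonyl-carbon position, so it does not bear on this change. Nothing measured here tests the amide side. The expectation is therefore set near compound 3, with a wide range in either direction. For compound 4 the estimate is 1500 nM, range 400 nM to 6000 nM, meaning an expected step of a 1.4-fold higher number from compound 3 to compound 4 (0.15 log units; within the scatter).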

Compound 4, half-maximal inhibitory concentration: 290 nM
Compound 4: the middle estimate sits 5.2-fold (0.71 log units) above what was measured; the whole stated range lies above it.
By their numbers in this assay, from the lowest: compound 1; then compound 2; then compound 4; then compound 3.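

The amide side is not silent in this assay: (oxolan-3-yl)amino in place of 3-methoxypyrrolidin-1-yl on a carbonyl carbon gives a 3.7-fold lower number from compound 3 to compound 4 (0.57 log units; beyond the scatter). The entering group carries 1 hydrogen-bond donor and the leaving group 0, but this single pair cannot separate the amide hydrogen from the other differences between the two groups. No available measurement accounts for the step.

From the compounds shown here alone, whether the step carries over to the core of compound 1 remains open. So does the outcome with an open-chain 2-methoxyethylamino group on the carbonyl carbon.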